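Methylamino replaces the chlorothiophenylethynyl group on the core

The compounds below may be only part of what the source reports. "The series", "measured", "known", "first", "only" and "open" are said of these compounds alone.

Of the compounds shown here, two have been tested in an assay on CHO cells for displacement of a labelled ligand from adenosine receptor A1 (Homo sapiens), read by scintillation counting, with a stated time of 60 min, tested at 10 uM; on this read-out higher numbers stand for more inhibition at the one concentration tested (going by the name of the read-out) and lower numbers for less inhibition. Compound 1 `CNC(=O)[C@@]12C[C@@H]1[C@@H](n1cnc3c(/C=C(\O)c4ccccc4Cl)nc(C#Cc4ccccc4Cl)nc31)[C@H](O)[C@@H]2O` gives 28% in this assay. Compound 2 `CNC(=O)[C@@]12C[C@@H]1[C@@H](n1cnc3cnc(C#Cc4ccc(Cl)s4)nc31)[C@H](O)[C@@H]2O` returns only a limit of the assay in this assay, < 10%, and so stands at the floor of the numbers shown (the limit of < 10% in this assay, at which 1 of the 2 values shown sits). Among the measured compounds shown here, compounds 1 and 2 differ from each other in more than one place, so no single step between them is available; only their two values can be set side by side. Compound 3 `CNC(=O)[C@@]12C[C@@H]1[C@@H](n1cnc3cnc(NC)nc31)[C@H](O)[C@@H]2O` has not yet been measured. It differs from compound 2 in one place: methylamino in place of 2-(5-chlorothiophen-2-yl)ethynyl on an aromatic carbon. The group that leaves is the larger of the two, and the methylamino that enters brings a hydrogen-bond donor. No shift in this assay beyond the usual scatter is expected from this change, and compound 3 is expected to remain at or near the limit. Compound 3 is estimated to give 7%, within 0% to 20%, which means a step that the limit leaves unreadable from compound 2 to compound 3 that is expected to stay within the scatter.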

Compound 3, a percentage reported as inhibition, at one concentration (the size of the read-out at that concentration, not a potency): 17%
Compound 3: middle estimate off by 10 percentage points, on the low side; the range from low to high includes it.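

In this assay, methylamino in place of 2-(5-chlorothiophen-2-yl)ethynyl on the aromatic carbon between two ring nitrogen atoms gives a number at least 7 percentage points higher from compound 2 to compound 3 (that floor lies within the scatter). Compound 3 gives a readable value of 17%, which shows that this position does not need the thiophene ring or the triple bond for a value to be read in this assay. The figure for compound 2 is a limit of the assay and not a number: the limit of < 10% in this assay, at which 1 of the 3 values shown sits.

As far as these compounds go, the size of the step remains unknown, and a single concentration gives no potency. From the compounds shown here alone, how an unsubstituted amine, dimethylamino, a longer chain such as propylamino, or a plain ethynyl group would read at this position remains open.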